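Removing one chloro from the dichlorophenyl arm of compound 2

This account rests on a few compounds, and the source may have more. Where it says the series, first, only, none or still open, it means among the compounds named here.

Three members of the series carry a methoxyphenyl arm on the shared core, and they differ in the second arm and in the ring nitrogen substituents. Compound 1 `COc1ccccc1/C=c1/[nH]c(=O)/c(=C\c2ccccc2OC)[nH]c1=O` bears two methoxyphenyl arms and unsubstituted ring nitrogens; in a functional assay on HL-60 cells (Homo sapiens) for cytotoxicity, read by CCK-8 assay, with a stated time of 72 h (on this read-out lower numbers stand for stronger inhibition and higher numbers for weaker inhibition), compound 1 gives "not active" (no number reported), with no number reported. Compound 2 `COc1ccccc1/C=c1\c(=O)[nH]/c(=C/c2cccc(Cl)c2Cl)c(=O)n1C` carries a 2,3-dichlorophenyl arm and a methyl on one ring nitrogen; in this assay compound 2 gives 200 nM. Compound 3 `C=CCn1c(=O)/c(=C\c2cc(F)ccc2C)[nH]c(=O)/c1=C\c1ccccc1OC` carries an allyl on one ring nitrogen and a fluoro-methylphenyl arm; in this assay compound 3 gives 2600 nM. Of the two numbers in hand, compound 2 holds the lower one, and the gap to compound 3 lies beyond the scatter.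

Compound 4 `COc1ccccc1/C=c1\c(=O)[nH]/c(=C/c2ccccc2Cl)c(=O)n1C` is the next step from compound 2. The change is hydrogen in place of chloro on an aromatic carbon, so the 2,3-dichlorophenyl arm becomes a 2-chlorophenyl arm while the methyl on the ring nitrogen stays. For the measured compounds named here, no measured pair isolates this change, so the direction of the step rests on the single anchor. With compound 2 at 200 nM, the number for compound 4 is expected to rise moderately, by a step of a 2.5-fold higher number from compound 2 to compound 4 (0.40 log units; beyond the scatter), which may still fall within the scatter. Compound 4 is therefore estimated at 500 nM, with a range from 150 nM to 2000 nM.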

Compound 4, half-maximal inhibitory concentration: 200 nM
Compound 4: the middle estimate sits 2.5-fold (0.40 log units) above what was measured; low and high end bracket the measured number.
By their numbers in this assay, from the lowest: compounds 2 and 4 (each within the scatter of the next); then compound 3.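

For the compounds shown here, the pair of compound 2 and compound 4 is the first to differ in one place, and in this assay hydrogen in place of chloro gives no change at the digits printed from compound 2 to compound 4 (within the scatter) on the arm that goes from 2,3-dichlorophenyl to 2-chlorophenyl. The chloro at this aromatic carbon, ortho to a chloro group and meta to a large group, is therefore not required for the read-out of this pair, and the 2-chlorophenyl arm serves as well as the 2,3-dichlorophenyl arm on this background. Nothing measured beyond the cell read-out bears on why this step is flat.

Still open, on these data alone, is whether the remaining chloro matters: on this background, a methoxy, an amine or a hydrogen at its place would show whether the arm needs any group there. Also open, as far as these compounds go, is the ring nitrogen, since compound 2 and compound 4 share the methyl and compound 1 and compound 3 differ from them in more than one place, so the amide hydrogen, the allyl or a longer chain such as butyl cannot yet be read against the methyl on the 2-chlorophenyl arm.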